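The source may hold more compounds than are shown below. What is called first, only, known or untested is meant among the compounds shown, and "the series" means these compounds.

Working notes on the series. All three measured compounds share one core; they differ in the group on the aryl ring of the piperazine-free... — rather, in the group on the terminal aromatic ring and in the length of the amine linker. Compound 1 `CCCc1nc(-c2ccccc2)c(CNCCN2CCN(c3cccc(C)c3)CC2)o1` carries a methyl on that ring with the shorter linker; in an assay on HEK293 cells for inhibition of Voltage-dependent T-type calcium channel subunit alpha-1G (Homo sapiens), read by fluorescence, tested at 10 uM (a lower number here means less inhibition, a higher number more inhibition at the concentration tested (going by the name of the read-out)), compound 1 gives 43.1%. Compound 3 `CCCc1nc(-c2ccccc2)c(CNCCN2CCN(c3cccc(OC)c3)CC2)o1` carries methoxy instead; in this assay compound 3 gives 40.2%, so a number 2.9 percentage points lower from compound 1 to compound 3 (within the scatter). Compound 2 `CCCc1nc(-c2ccccc2)c(CNCCCN2CCN(c3cccc(OC)c3)CC2)o1` keeps the methoxy with the longer linker; in this assay compound 2 gives 36.4%, the lowest of the three numbers, though within the scatter of both compound 3 and compound 1. Compound 4 `CCCc1nc(-c2ccccc2)c(CNCCCN2CCN(c3ccccc3)CC2)o1` differs from compound 2 by hydrogen in place of methoxy on an aromatic carbon. Among the compounds with values here, no measured step removes the methoxy entirely; the nearest comparison is the exchange of methyl for methoxy, a number 2.9 percentage points lower from compound 1 to compound 3 (within the scatter), which stayed within the scatter. For compound 4 a step of similar size, with no direction beyond the scatter, is therefore expected, a number 0.6 percentage points higher from compound 2 to compound 4 (within the scatter). Compound 4 is estimated at 37%, between 25% and 50%.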

Compound 4, a percentage reported as inhibition, at one concentration (the size of the read-out at that concentration, not a potency): 43.7%
Compound 4: the middle estimate sits 6.7 percentage points below what was measured; the measured number falls inside the stated range.
By their numbers in this assay, from the lowest: compounds 2, 3, 1 and 4 (each within the scatter of the next).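

At this place on the aromatic ring, the change from 3-methoxyphenyl to phenyl gives a number 7.3 percentage points higher from compound 2 to compound 4 (within the scatter) in this assay, so a ring with hydrogen in place of methoxy cannot be told apart from the methoxy ring with the longer linker. Within the data shown here, this is the first step to leave the position without a substituent, and, like a number 2.9 percentage points lower from compound 1 to compound 3 (within the scatter) with the shorter linker, it stays inside the scatter, so hydrogen, methyl and methoxy at this place give no separable step in the two pairs available. No measurement bears on why the exchange behaves this way.

On these data alone, it remains open whether a carboxylic acid or an amine at this place would give a step beyond the scatter. Also open, as far as these compounds go, is whether hydrogen in place of methoxy reads the same with the shorter linker.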